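Replacing 4-Ethylphenyl with Octyl: Outlook for Cytotoxicity

The source may hold more compounds than are shown below. What is called first, only, known or untested is meant among the compounds shown, and "the series" means these compounds.

Measured so far:
- Compound 1 `CCCc1ccc(-c2cc3cn([C@H]4C[C@H](O)[C@@H](CO)O4)c(=O)nc3s2)cc1` gives 80000 nM in a functional assay on HeLa cells (Homo sapiens) for cytotoxicity, read by microscopy; on this read-out lower numbers stand for higher toxicity in this test and higher numbers for lower toxicity in this test.
- Compound 2 `CCc1ccc(-c2cc3cn([C@H]4C[C@H](O)[C@@H](CO)O4)c(=O)nc3s2)cc1` reaches only the assay limit of > 200000 nM in this assay.

Compound 2 therefore stands at the top of the numbers shown: for it there is no number, only a limit, which is the same limit described by the limit of > 200000 nM in this assay, at which 1 of the 2 values shown sits. For the measured compounds named here, the one measured step, an at least 2.5-fold higher number from compound 1 to compound 2 (0.39 log units; beyond the scatter), shows that shortening the chain on the ring moved the compound from a measured value to a value beyond the range of this assay.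

Compound 3 `CCCCCCCCc1cc2cn([C@H]3C[C@H](O)[C@@H](CO)O3)c(=O)nc2s1` differs from compound 2 by octyl in place of 4-ethylphenyl on an aromatic carbon. Going by the values given here, no measured step concerns the exchange of a ring for a chain, so the single known step gives only indirect guidance. Since compound 2 sits at the limit, an expected change in either direction within the scatter cannot be separated from no change at all. Compound 3 is expected to give about 150000 nM in this assay, with a range from 50000 nM to 400000 nM. This corresponds to an expected step of an at least 1.3-fold lower number from compound 2 to compound 3 (0.12 log units; that floor lies within the scatter).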

Compound 3, minimum cytotoxic concentration: 20000 nM
Compound 3: the middle estimate sits 7.5-fold (0.88 log units) above what was measured; measured number below the stated range.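

In this assay, the group on the aromatic carbon next to the ring sulfur can do more than set a limit or a weak reading. Octyl in place of 4-ethylphenyl, both with 8 heavy atoms, gives an at least 10-fold lower number from compound 2 to compound 3 (1.00 log units; beyond the scatter), so a chain with no ring can carry much more toxicity in this test than an aromatic ring bearing a short chain. The comparison with 4-propylphenyl has measured numbers on both sides and gives a 4.0-fold lower number from compound 1 to compound 3 (0.60 log units; beyond the scatter), while the step from compound 2 is only a floor, because compound 2 has a limit and not a number: the limit of > 200000 nM in this assay, at which 1 of the 3 values shown sits.

The compounds shown do not separate the loss of the ring from the length of the chain, since octyl differs from both other groups in its shape as well as in its atoms. A shorter chain such as butyl, a longer chain such as dodecyl, or 4-octylphenyl on the same carbon would show whether the number follows chain length alone or also depends on the aromatic ring.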